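The compounds below may be only part of what the source reports. "The series", "measured", "known", "first", "only" and "open" are said of these compounds alone.

Three compounds have been measured in an ADME assay on MT4 cells (Homo sapiens) for activation, read by MTT assay; a lower number here means that less compound is tolerated, a higher number that more compound is tolerated:

Compound 1, `CCC(C)Sc1nc(C(C)c2c(F)cccc2Cl)cc(=O)[nH]1`, gives > 73000 nM, which is a limit of the assay and not a number.
Compound 2, `CCCCSc1nc(C(C)c2c(F)cccc2Cl)cc(=O)[nH]1`, gives > 73000 nM, again a limit rather than a number.
Compound 3, `CCc1c(C(C)c2c(F)cccc2F)nc(SC(C)CC)[nH]c1=O`, gives > 3000 nM, also a limit.

Compound 1 and compound 2 share one core and differ in a single place: butyl in place of sec-butyl on a sulfur. The step that the two limits leave unreadable from compound 1 to compound 2 cannot be sized because the limit of > 73000 nM in this assay, at which 2 of the 3 values shown sit, is where both values sit. Compound 3 is built on a different core; the difference between the two cores is not broken down here. Among the measured compounds shown here, for compound 3 only a limit is known, (the limit of > 3000 nM in this assay, at which 1 of the 3 values shown sits), and the other two values shown are limits as well, so no measured step involves compound 3.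

Compound 4, `CCCCSc1nc(C(C)c2c(F)cccc2F)c(CC)c(=O)[nH]1`, has not yet been measured. It differs from compound 3 by butyl in place of sec-butyl on a sulfur, the same change that separates compound 1 from compound 2, made at the same kind of place. Since that earlier step was left unreadable by the two limits, the measured data give no direction for it. Compound 4 is therefore expected to be tolerated at roughly 60000 nM in this assay, between 5000 nM and 200000 nM. The expected step that the limit leaves unreadable from compound 3 to compound 4 is thus small and itself uncertain. This expectation rests on compound 3 giving > 3000 nM. It also rests on compound 1 and compound 2 both sitting at the limit of > 73000 nM in this assay, at which 2 of the 3 values shown sit, which suggests that, most likely, this assay will report only a limit for compound 4 too.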

Compound 4, half-maximal cytotoxic concentration: > 3000 nM
Compound 4 was reported as a limit; the forecaster's own chance of this, stated with the estimate: 80%; the middle value does not contradict the limit.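

Compound 3 and compound 4 are both reported in this assay only as limits and not as numbers, so no size can be read for the change from sec-butyl to butyl on the sulfur. The compounds shown leave open whether this change shifts the tolerated concentration at all, and at what actual concentration any of the four compounds becomes toxic to the cells.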